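The compounds below may be only part of what the source reports. "The series", "measured", "known", "first", "only" and "open" are said of these compounds alone.

Working notes on the series in a functional assay on HeLa S3 cells (Homo sapiens) for antiproliferative activity, read by XTT assay, with a stated time of 72 h; on this read-out higher numbers stand for weaker inhibition and lower numbers for stronger inhibition.

Compound 1 `COc1ncnc2c1c(I)cn2[C@@H]1O[C@H](CO)[C@@H](O)[C@H]1O` carries an iodo on the shared core and gives 14300 nM. Compound 2 `COc1ncnc2c1c(-c1cccs1)cn2[C@@H]1O[C@H](CO)[C@@H](O)[C@H]1O` gives 1760 nM. Within the data shown here, the one measured step, an 8.1-fold lower number from compound 1 to compound 2 (0.91 log units; beyond the scatter), is thiophen-2-yl in place of iodo on an aromatic carbon.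

Among the measured compounds shown here, compound 3 `CNc1ncnc2c1c(-c1ccsc1)cn2[C@@H]1O[C@H](CO)[C@@H](O)[C@H]1O` reaches only the limit of the measurement, > 20000 nM, so no number is known for it; it is the one compound sitting at the limit of > 20000 nM in this assay, at which 1 of the 3 values shown sits.

Compound 4 `COc1ncnc2c1c(-c1ccsc1)cn2[C@@H]1O[C@H](CO)[C@@H](O)[C@H]1O` is the next compound to be measured. The change from compound 3 to compound 4 is methoxy in place of methylamino on an aromatic carbon. For the measured compounds named here, no measured step bears directly on this exchange: the step from compound 1 to compound 2 concerns a different position, and compound 3 offers only a limit as a starting point. Going by the values given here, the only methoxy compound with a thiophene, compound 2, gives 1760 nM. The expectation for compound 4 is therefore a number of that order, estimated at 4000 nM with a range of 1000 nM to 20000 nM, which would mean an expected step of an at least 5.0-fold lower number from compound 3 to compound 4 (0.69 log units; beyond the scatter).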

Compound 4, half-maximal inhibitory concentration: 3350 nM
For compound 4 the middle estimate is 1.2-fold (0.08 log units) above the measured one; the range from low to high includes it.
By their numbers in this assay, from the lowest: compounds 2 and 4 (each within the scatter of the next); then compound 1. At a limit, above all of these: compound 3.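

In this assay, among these compounds, methoxy in place of methylamino on the aromatic carbon next to the ring nitrogen gives an at least 5.9-fold lower number from compound 3 to compound 4 (0.77 log units; beyond the scatter), the first reading of a change at this place. Compound 3 stands only at a limit, so this step has a bound and no exact size: the limit of > 20000 nM in this assay, at which 1 of the 4 values shown sits. The thiophene attachment shows a 1.9-fold higher number from compound 2 to compound 4 (0.28 log units; within the scatter), so thiophen-2-yl and thiophen-3-yl are not told apart here, while a 4.3-fold lower number from compound 1 to compound 4 (0.63 log units; beyond the scatter) shows that the lower number relative to iodo also holds for thiophen-3-yl.

Open, going by these compounds, is whether the exchange holds with iodo or thiophen-2-yl in place of thiophen-3-yl. Also open, on these data alone, is what an amino, dimethylamino or ethoxy group would give in place of methoxy, and what phenyl would give in place of the thiophene.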